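The compounds below may be only part of what the source reports. "The series", "measured", "known", "first", "only" and "open" are said of these compounds alone.

Measured so far in a functional assay on the whole organism for inhibition, with Rattus norvegicus as the target, read by paw edema; on this read-out higher numbers stand for an effect only at larger amounts of compound and lower numbers for an effect already at smaller amounts:
compound 1, `O=C(O)c1cc(-n2cccc2)ccc1O`, gives 50 mg/kg
compound 2, `O=C(O)c1cc(-c2nccs2)ccc1O`, gives only a limit of the assay, > 250 mg/kg
compound 3, `O=C(O)c1cc(-n2cccn2)ccc1O`, gives 200 mg/kg

Among these, compound 3 stands at the highest of the two plain numbers; the nearest is compound 1, separated by a 4.0-fold higher number from compound 1 to compound 3 (0.60 log units; beyond the scatter). The remaining value is the limit of > 250 mg/kg in this assay, at which 1 of the 3 values shown sits, and it belongs to compound 2.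

Compound 4, `O=C(O)c1cc(-n2cnnc2)ccc1O`, differs from compound 3 in one place: 4H-1,2,4-triazol-4-yl in place of 1H-pyrazol-1-yl on an aromatic carbon. The entering ring carries more nitrogen and more hydrogen-bond acceptors than the leaving one. Among the compounds with values here, two measured steps concern swaps of the same azole: a 4.0-fold higher number from compound 1 to compound 3 (0.60 log units; beyond the scatter) and an at least 5.0-fold higher number from compound 1 to compound 2 (0.69 log units; beyond the scatter). Both moves from the pyrrolyl ring toward a ring with more hetero atoms raised the number beyond the scatter, and none of the three compounds goes against that. Between compound 2 and compound 3 the difference, an at least 1.2-fold lower number from compound 2 to compound 3 (0.09 log units; that floor lies within the scatter), stays within the scatter. Since the step to compound 4 continues in the same direction, a modest further rise, or at least no fall, is expected: a 1.5-fold higher number from compound 3 to compound 4 (0.18 log units; within the scatter). Compound 4 is therefore estimated at about 300 mg/kg, somewhere between 150 mg/kg and 600 mg/kg, with a real chance that this assay reports only a limit.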

Compound 4, dose for half-maximal effect: > 250 mg/kg
Compound 4 ended at the assay's limit (the forecaster's own chance of this, stated with the estimate: 50%); the middle value lies beyond the limit too.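

In this assay, the 4H-1,2,4-triazol-4-yl ring, meta to a carboxy group and para to a hydroxy group, joins the other two replacements for the 1H-pyrrol-1-yl ring in giving a higher number, and no compound shown goes against this: an at least 5.0-fold higher number from compound 1 to compound 4 (0.69 log units; beyond the scatter). Going from 1H-pyrazol-1-yl to 4H-1,2,4-triazol-4-yl adds a ring nitrogen, yet the data show no change beyond the scatter, since an at least 1.2-fold higher number from compound 3 to compound 4 (0.09 log units; that floor lies within the scatter) gives only a floor for the true step. Compound 4 gives a limit of the assay rather than a number, so its step from compound 2, which also gives a limit, cannot be read, and the top of this small series is no longer resolved: the limit of > 250 mg/kg in this assay, at which 2 of the 4 values shown sit.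

The compounds shown leave open whether this place needs an aromatic ring with hetero atoms at all, since a phenyl ring or a propyl chain could give a number near that of compound 1 or a much higher one. Compound 1 gives 50 mg/kg. They also cannot tell why the 1H-pyrrol-1-yl ring gives the lowest plain number here.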